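Methoxy added to the hydroxyphenyl thiosemicarbazone

The compounds below may be only part of what the source reports. "The series", "measured", "known", "first", "only" and "open" are said of these compounds alone.

Compound 1, with the structure `CC1=CC[C@H](C(C)(C)NC(=S)N/N=C/c2ccc(O)cc2)CC1`, is the parent of this small series. In a functional assay on 786-0 cells (Homo sapiens) for inhibition, read by sulforhodamine B assay, with a stated time of 48 h (on this read-out lower numbers stand for stronger inhibition of growth and higher numbers for weaker inhibition of growth), compound 1 gives only a limit, > 100000 nM, and no number. Compound 2, `CC1=CC[C@H](C(C)(C)NC(=S)N/N=C/c2ccc(F)cc2)CC1`, likewise gives only a limit in this assay, > 100000 nM. Among the compounds with values here, compound 3, `CC1=CC[C@H](C(C)(C)NC(=S)N/N=C/c2cccc(Cl)c2)CC1`, is the one member with a number, giving 9200 nM in this assay. The step from compound 1 to compound 2 is a step that the two limits leave unreadable from compound 1 to compound 2, while the steps of an at least 10-fold lower number from compound 1 to compound 3 (1.03 log units; beyond the scatter) and an at least 10-fold lower number from compound 2 to compound 3 (1.03 log units; beyond the scatter) are the only readable ones; both point to the limit of > 100000 nM in this assay, at which 2 of the 3 values shown sit, which is where compound 1 sits.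

Compound 4, `COc1cc(/C=N/NC(=S)NC(C)(C)[C@H]2CC=C(C)CC2)ccc1O`, differs from compound 1 by methoxy in place of hydrogen on an aromatic carbon. Within the data shown here, no measured step changes a group on the ring of compound 1 while keeping the hydroxy group, so nothing bears directly on this change. Since compound 1 sits at the limit, compound 4 is expected to give a value near that limit as well, with the step of a number no higher from compound 1 to compound 4 (the limit leaves the size open). The estimate for compound 4 is therefore 100000 nM, between 30000 nM and 300000 nM, most likely reported again only as a limit.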

Compound 4, concentration for 50% growth inhibition: 12900 nM
The estimate for compound 4 lay 7.8-fold (0.89 log units) above the measured number; the whole stated range lies above it.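

In this assay, methoxy in place of hydrogen on an aromatic carbon, ortho to a hydroxy group, gives an at least 7.7-fold lower number from compound 1 to compound 4 (0.88 log units; beyond the scatter). Within the data shown here, the earlier readable steps all replaced the whole substituted phenyl group with 3-chlorophenyl, whereas this one keeps the hydroxy group and changes only a single ring position. A hydroxyphenyl compound can therefore have a readable number, and one added group on the ring is enough to bring it off the limit that compound 1 shares with compound 2: the limit of > 100000 nM in this assay, at which 2 of the 4 values shown sit.

The compounds shown leave open whether compound 4 needs its hydroxy group alongside the methoxy. They also leave open whether the effect belongs to methoxy itself or would also follow from ethoxy, an amine or a carboxylic acid at the same position.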